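Methyl additions on a tricyclic indole ester series

The source may hold more compounds than are shown below. What is called first, only, known or untested is meant among the compounds shown, and "the series" means these compounds.

Measured compounds:
Compound 1 `COC(=O)[C@@]1(C)CCC=C2[C@@H]1CC[C@@H](C)[C@]2(C)Cc1c[nH]c2ccc(C)cc12` gives 22000 nM in a functional assay on WiDr cells (Homo sapiens) for inhibition, read by sulforhodamine B assay, with a stated time of 48 h; on this read-out lower numbers stand for stronger inhibition of growth and higher numbers for weaker inhibition of growth.
Compound 2 `COC(=O)[C@@]1(C)CCC=C2[C@@H]1CC[C@@H](C)[C@]2(C)Cc1c(C)[nH]c2ccccc12` gives 19000 nM in this assay.

Compound 2 and compound 1 sit within the usual scatter of one another in this assay, so neither can be set apart. Compound 3 `COC(=O)[C@@]1(C)CCC=C2[C@@H]1CC[C@@H](C)[C@]2(C)Cc1c(C)[nH]c2ccc(C)cc12` carries both methyl groups of the earlier pair on one core; relative to compound 2 the change is methyl in place of hydrogen on an aromatic carbon. Within the data shown here, no measured pair isolates this change. Compound 1 shows that a methyl at this place is tolerated, so the step from compound 2 to compound 3 is expected to be small and without direction beyond the scatter, a 1.1-fold lower number from compound 2 to compound 3 (0.05 log units; within the scatter). Compound 3 is estimated at 17000 nM, between 8000 nM and 36000 nM.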

Compound 3, concentration for 50% growth inhibition: 28000 nM
Beside the measured number, compound 3's estimate is 1.6-fold (0.22 log units) below it, and the stated range covers the measured number.
By their numbers in this assay, from the lowest: compounds 2, 1 and 3 (each within the scatter of the next).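

In this assay, the series now has its first pairs differing in one place: methyl in place of hydrogen on an aromatic carbon of the six-membered ring gives a 1.5-fold higher number from compound 2 to compound 3 (0.17 log units; within the scatter), and the other methyl gives a 1.3-fold higher number from compound 1 to compound 3 (0.10 log units; within the scatter). Neither step sets the compounds apart, so carrying both methyl groups on one core leaves the read-out within the scatter of each single-methyl compound. Nothing available bears on the reason for this. Going by these compounds, whether an amine or a carboxylic acid at this aromatic carbon would separate from the methyl compounds remains open.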